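Pyridinyl for Methyl on the Piperazine Terminus

A few compounds are considered here, and "the series" means these few. Any claim that something is new, unique, unknown or untested is made for them only; others in the source may bear on it.

Compound 1 `COc1cc2c(Nc3ccc(C#N)cc3)ncnc2cc1OCCCN(C)C` gives 34900 nM in a functional assay on SH-SY5Y cells (Homo sapiens) for antiproliferative activity, read by MTT assay, with a stated time of 72 h; a lower number here means a stronger inhibitor, a higher number a weaker inhibitor.
Compound 2 `COc1cc2c(Nc3ccc(C#N)cc3)ncnc2cc1OCCCN1CCC(N2CCCCC2)CC1` gives 9810 nM in this assay.
Compound 3 `COc1cc2c(Nc3ccc(C#N)cc3)ncnc2cc1OCCCN1CCN(C)CC1` gives 13000 nM in this assay.

Compound 3 stands second highest of the three numbers in this assay, close to compound 2, with a 1.3-fold higher number from compound 2 to compound 3 (0.12 log units; within the scatter), while a 2.7-fold lower number from compound 1 to compound 3 (0.43 log units; beyond the scatter) lies beyond the scatter. Compound 4 `COc1cc2c(Nc3ccc(C#N)cc3)ncnc2cc1OCCCN1CCN(c2ccncc2)CC1` differs from compound 3 only in that (pyridin-4-yl in place of methyl on an amine nitrogen in a ring). Among the compounds with values here, no measured step touches this exact exchange; the nearest evidence is the terminal-group series at the end of the three-carbon chain, where a 3.6-fold lower number from compound 1 to compound 2 (0.55 log units; beyond the scatter) and a 2.7-fold lower number from compound 1 to compound 3 (0.43 log units; beyond the scatter), two modest gains, and where the larger group in compound 2 differs from compound 3 only within the scatter. Enlarging the group at the end of the chain has therefore given at most a modest change, and the piece expects compound 4 to show little movement, with a 1.3-fold lower number from compound 3 to compound 4 (0.11 log units; within the scatter) as the estimated step. Compound 4 is estimated at 10000 nM, within a range from 4000 nM to 30000 nM.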

Compound 4, half-maximal inhibitory concentration: 31600 nM
The estimate for compound 4 lay 3.2-fold (0.50 log units) below the measured number, outside the stated range (above it).
By their numbers in this assay, from the lowest: compounds 2 and 3 (each within the scatter of the next); then compounds 4 and 1 (each within the scatter of the next).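

In this assay, within the data shown here, this position, which had so far tolerated a change of terminal group, responds to pyridin-4-yl in place of methyl on an amine nitrogen in a ring, with a 2.4-fold higher number from compound 3 to compound 4 (0.39 log units; beyond the scatter) as a modest rise that the earlier compounds did not show. The 4-(pyridin-4-yl)piperazin-1-yl group also gives a 3.2-fold higher number from compound 2 to compound 4 (0.51 log units; beyond the scatter) against the larger 4-(piperidin-1-yl)piperidin-1-yl group, while a 1.1-fold lower number from compound 1 to compound 4 (0.04 log units; within the scatter) leaves it level with dimethylamino, so a larger terminal group does not by itself go with a lower number. No measured evidence bears on why this exchange acts as it does.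

Going by these compounds, what a phenyl or a benzyl group would give on this nitrogen remains open. The compounds shown therefore do not separate the effect of the aromatic ring from that of its nitrogen.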